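The compounds below may be only part of what the source reports. "The series", "measured", "known", "first", "only" and "open" are said of these compounds alone.

Measured in a functional assay on HEL cells (Homo sapiens); a higher number here means that more compound is tolerated, a lower number that less compound is tolerated:

- compound 1 `CC(=O)NC1=CS(=O)(=O)O[C@@]12[C@@H](CO[Si](C)(C)C(C)(C)C)O[C@@H](n1cc(C)c(=O)n(C)c1=O)[C@@H]2O[Si](C)(C)C(C)(C)C` gives > 200000 nM (a limit of the assay, not a number)
- compound 2 `Cc1cn([C@@H]2O[C@H](CO[Si](C)(C)C(C)(C)C)[C@@]3(OS(=O)(=O)C=C3NC(=O)c3ccccc3)[C@H]2O[Si](C)(C)C(C)(C)C)c(=O)n(C)c1=O` gives 9700 nM

Among the measured compounds shown here, compound 2, at 9700 nM, carries the only true number so far. The reading for compound 1 is a limit, (the limit of > 200000 nM in this assay, at which 1 of the 2 values shown sits), so the scale has just one firm point.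

The next compound, compound 3 `Cc1cn([C@@H]2O[C@H](CO[Si](C)(C)C(C)(C)C)[C@@]3(OS(=O)(=O)C=C3NCCC(=O)OCc3ccccc3)[C@H]2O[Si](C)(C)C(C)(C)C)c(=O)n(C)c1=O`, has 2-(benzyloxycarbonyl)ethyl in place of benzoyl on an amine nitrogen.

For the measured compounds named here, only one measured step offers any guidance. It is an at least 20-fold lower number from compound 1 to compound 2 (1.31 log units; beyond the scatter), a large step that came with phenyl in place of methyl on a carbonyl carbon. That step is only a loose guide, since the present change replaces a whole group on the amine nitrogen. Even so, the group entering compound 3 still holds a six-membered aromatic ring of carbon only, as the benzoyl group of compound 2 does, so a return to the limit seen for compound 1 seems unlikely.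

No step beyond the scatter is expected, and the estimated step is a 1.4-fold higher number from compound 2 to compound 3 (0.16 log units; within the scatter). Compound 3 is expected near 14000 nM, with an estimated range from 5000 nM to 60000 nM.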

Compound 3, half-maximal cytotoxic concentration: 200000 nM
Compound 3: middle estimate off by 14-fold (1.15 log units), on the low side; measured number above the stated range.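

Keeping a six-membered aromatic ring of carbon only on the amine nitrogen is not enough to hold the number in this assay: 2-(benzyloxycarbonyl)ethyl in place of benzoyl gives a 21-fold higher number from compound 2 to compound 3 (1.31 log units; beyond the scatter). The ring therefore cannot be read on its own, and the whole group on this nitrogen has to be considered; among the three groups shown, benzoyl alone goes with a clearly lower number, with less compound tolerated. 2-(Benzyloxycarbonyl)ethyl in place of acetyl gives a number no higher from compound 1 to compound 3 (the limit leaves the size open) and the size of this step cannot be read. The reading for compound 1 is a limit and not a number: the limit of > 200000 nM in this assay, at which 1 of the 3 values shown sits.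

The new group differs from benzoyl in several ways at once, with a longer chain, an ester and no carbonyl directly on the nitrogen, so the compounds shown do not tell which of these differences goes with the step. A simple benzyl group on the same nitrogen, or a 2-carboxyethyl group, would help separate the role of the ring from that of the chain and the ester.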